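The compounds below may be only part of what the source reports. "The series", "measured", "known", "first", "only" and "open" are said of these compounds alone.

Compound 1, `O=c1ccoc2cc(OCc3cn(Cc4ccc(Cl)cc4)nn3)ccc12`, in a functional assay on SW480 cells (Homo sapiens) for cytotoxicity, read by MTT assay, with a stated time of 48 h (a lower number here means a stronger inhibitor, a higher number a weaker inhibitor), gives > 100000 nM, a limit of the assay and not a number. Compound 2, `O=c1ccoc2cc(OCc3cn(Cc4cccc(Br)c4)nn3)ccc12`, in this assay gives > 100000 nM, again a limit. Compound 3, `O=c1ccoc2cc(OCc3cn(Cc4cccc(F)c4)nn3)ccc12`, in this assay gives > 100000 nM, also a limit.

For the measured compounds named here, compound 3 therefore stands at no measured position at all: its value is a limit, and the two other values shown are limits as well, so no compound among the three can be placed above or below another. The measured steps say the same. The step that the two limits leave unreadable from compound 1 to compound 2 cannot be read, nor can a step that the two limits leave unreadable from compound 1 to compound 3 or a step that the two limits leave unreadable from compound 2 to compound 3; all three sit at the limit of > 100000 nM in this assay, at which 3 of the 3 values shown sit.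

Compound 4, `O=c1ccoc2cc(OCc3cn(Cc4cccc([N+](=O)[O-])c4)nn3)ccc12`, differs from compound 3 by nitro in place of fluoro on an aromatic carbon. The step most closely related to this is a step that the two limits leave unreadable from compound 2 to compound 3, a halogen exchange on the same aromatic carbon, and it is unreadable. Nothing measured here speaks for a change beyond the scatter in this assay when the fluoro becomes a nitro, and every value shown so far is a limit. Compound 4 is expected to show a step that the limit leaves unreadable from compound 3 to compound 4, and so to give an estimated 150000 nM, between 50000 nM and 500000 nM, most probably again reported only as a limit.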

Compound 4, half-maximal inhibitory concentration: > 100000 nM
Compound 4: a limit, no number (the forecaster's own chance of this, stated with the estimate: 80%); the middle value is on the limit's open side.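

For the compounds shown here, compound 4 also gives only a limit, so no step among compound 1, compound 2, compound 3 and compound 4 can be read in this assay, and all four remain unordered: the limit of > 100000 nM in this assay, at which 4 of the 4 values shown sit. The compounds shown leave open how these four compare and whether any group on the phenyl ring gives a measurable value in this assay.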